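Aryl Substituent Exchange on a Weak Dipeptidyl Peptidase 9 Inhibitor

The compounds below may be only part of what the source reports. "The series", "measured", "known", "first", "only" and "open" are said of these compounds alone.

The series shares one core, seen in compound 1 `CC#CCn1c(N2CCC[C@@H](N)C2)cc(=O)n(Cc2cccc(C(=O)O)c2F)c1=O` and compound 2 `CC#CCn1c(N2CCC[C@@H](N)C2)cc(=O)n(Cc2ccc(F)c(C(=O)O)c2)c1=O`, which differ only in the substitution of the benzyl ring. In an assay on isolated protein for inhibition of Dipeptidyl peptidase 9 (Homo sapiens), read by fluorescence, with stated times of 15 min and 20 min (a higher number here means a weaker inhibitor, a lower number a stronger inhibitor), compound 1 has no reported result, with the entry reading "not determined" (no result reported). For compound 2 in this assay only a limit is recorded, > 100 nM, and that is not a number. For the measured compounds named here, compound 2 therefore sits at the limit of > 100 nM in this assay, at which 1 of the 2 values shown sits, with no single figure beside it for comparison and no measured step to any other compound.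

Compound 3 `CC#CCn1c(N2CCC[C@@H](N)C2)cc(=O)n(Cc2cc(Br)cc(C(=O)O)c2)c1=O` is the next member and is not yet measured in this assay. It differs from compound 2 by 3-bromo-5-carboxyphenyl in place of 3-carboxy-4-fluorophenyl on a saturated chain carbon bound to an aromatic nitrogen. Going by the values given here, with no measured step to build on, and compound 2 giving only a limit, the step from compound 2 to compound 3 in this assay is expected to be small, no larger than the usual scatter, and the result for compound 3 is expected to remain weak, so that a step that the limit leaves unreadable from compound 2 to compound 3 is the estimated change. Compound 3 is estimated at 300 nM in this assay, within a range from 80 nM to 3000 nM, with a real chance that again only a limit is reported.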

Compound 3, half-maximal inhibitory concentration: > 100 nM
Compound 3 ended at the assay's limit; the forecaster's own chance of this, stated with the estimate: 60%; the middle value does not contradict the limit.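

Compound 2 and compound 3 each carry only a limit, not a number, in this assay, so no step can be read between them. The compounds shown leave open how strongly compound 2 and compound 3 actually inhibit in this assay, and whether exchanging 3-carboxy-4-fluorophenyl for 3-bromo-5-carboxyphenyl changes that inhibition at all.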